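Cyclopropyl in place of 3-methoxyphenyl on the amide nitrogen

The compounds below may be only part of what the source reports. "The series", "measured", "known", "first", "only" and "open" are said of these compounds alone.

Measured compounds:
Compound 1, `COc1cccc(N2C(=O)COc3ccc(-c4cnc(Cl)c(NS(=O)(=O)c5ccc(F)cc5)c4)cc32)c1`: in a functional assay on MCF7 cells (Homo sapiens) for antiproliferative activity, read by MTT assay, with a stated time of 72 h (on this read-out lower numbers stand for stronger inhibition and higher numbers for weaker inhibition), compound 1 is recorded only as a limit, > 40000 nM.
Compound 2, `O=C1COc2ccc(-c3cccc(NS(=O)(=O)c4ccc(F)cc4)c3)cc2N1`: compound 2 gives 18300 nM.
Compound 3, `COc1cccc(N2C(=O)COc3ccc(-c4cnc(OC)c(NS(=O)(=O)c5ccc(F)cc5)c4)cc32)c1`: compound 3 is recorded only as a limit, > 40000 nM.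

Compound 1 stands at the limit of the read-out, with no number of its own; (the limit of > 40000 nM in this assay, at which 2 of the 3 values shown sit). Going by the values given here, the one single-point step among the measured compounds, a step that the two limits leave unreadable from compound 1 to compound 3, runs between two limits and has no readable size. Compound 4, `O=C1COc2ccc(-c3cnc(Cl)c(NS(=O)(=O)c4ccc(F)cc4)c3)cc2N1C1CC1`, differs from compound 1 as follows: cyclopropyl in place of 3-methoxyphenyl on an amide-type nitrogen in a ring. Among the compounds with values here, no measured step touches the group on the amide-type nitrogen, so the size of this step in this assay cannot be read from the measured pairs. Within the data shown here, compound 2, which carries hydrogen on that nitrogen together with other differences, gives a number rather than a limit, but no single-point step connects it to compound 1 or compound 4. Compound 4 is expected to sit near the same limit as compound 1, an at least 1.1-fold lower number from compound 1 to compound 4 (0.05 log units; that floor lies within the scatter), with a real chance that only a limit is again reported. The estimate for compound 4 is 35000 nM, between 10000 nM and 100000 nM.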

Compound 4, half-maximal inhibitory concentration: 16700 nM
Beside the measured number, compound 4's estimate is 2.1-fold (0.32 log units) above it, within the range that was stated.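

In this assay, going by these compounds alone, the group on the amide-type nitrogen is the first place where a single change gives a readable step: an at least 2.3-fold lower number from compound 1 to compound 4 (0.37 log units; beyond the scatter). With cyclopropyl in place of 3-methoxyphenyl, 3 heavy atoms stand where 8 stood and the aromatic ring is gone, yet compound 4 gives a number, so the 3-methoxyphenyl group is not needed for a measurable value on this core. Compound 1 is recorded only as a limit, so this step is a floor and not a full size: the limit of > 40000 nM in this assay, at which 2 of the 4 values shown sit.

Going by these compounds, how a longer chain, such as n-butyl, or an aminoethyl group would read on that nitrogen stays open. On these data alone, the step from chloro to methoxy runs between two limits and cannot be read, so whether that change matters with cyclopropyl on the nitrogen also stays open.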